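Methoxy in Place of Methylsulfanyl: Expected Cytotoxicity

The compounds below may be only part of what the source reports. "The series", "measured", "known", "first", "only" and "open" are said of these compounds alone.

Measured so far:
Compound 1 `CC(C)=CCOc1cc(Nc2ncccn2)ccc1Cl` gives 2500 nM in a functional assay on MT2 cells (Homo sapiens) for cytotoxicity, read by MTT assay; on this read-out lower numbers stand for higher toxicity in this test and higher numbers for lower toxicity in this test.
Compound 2 `CC(C)=CCOc1cc(Nc2nccc(C)n2)ccc1Cl` reaches only a limit of this assay, < 200 nM, not a number.
Compound 3 `CSc1ccnc(Nc2ccc(Cl)c(OCC=C(C)C)c2)n1` gives 2800 nM in this assay.

Compound 3 shows the highest number of the two numbers given; compound 1 is nearest, and the two lie within the scatter, so they cannot be told apart. Compound 2 sits at a limit, (the limit of < 200 nM in this assay, at which 1 of the 3 values shown sits).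

Compound 4 `COc1ccnc(Nc2ccc(Cl)c(OCC=C(C)C)c2)n1` differs from compound 3 in one place: methoxy in place of methylsulfanyl on an aromatic carbon.

Within the data shown here, two measured steps touch the same place. The step of a 1.1-fold higher number from compound 1 to compound 3 (0.05 log units; within the scatter) shows that methylsulfanyl in place of hydrogen changed nothing beyond the scatter. The step of an at least 14-fold higher number from compound 2 to compound 3 (1.14 log units; beyond the scatter) shows that methylsulfanyl in place of methyl gave a large rise. Nothing measured shows methoxy at this place, so the expectation rests on the neighbouring groups alone. Methoxy is counted like methylsulfanyl in size and acceptors, so compound 4 is estimated to stay near compound 3, with a step of a 1.4-fold lower number from compound 3 to compound 4 (0.15 log units; within the scatter) within the scatter. Compound 4 is therefore expected to give 2000 nM, between 500 nM and 6000 nM.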

Compound 4, half-maximal cytotoxic concentration: 9000 nM
The estimate for compound 4 lay 4.5-fold (0.65 log units) below the measured number; the measured number lies above the stated range.
By their numbers in this assay, from the lowest: compounds 1 and 3 (each within the scatter of the next); then compound 4. At a limit, below all of these: compound 2.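

At this place on the ring, next to the ring nitrogen, two groups with the same count of heavy atoms and hydrogen-bond acceptors do not behave alike in this assay: swapping methylsulfanyl for methoxy gives a 3.2-fold higher number from compound 3 to compound 4 (0.51 log units; beyond the scatter). Methoxy in place of hydrogen gives a 3.6-fold higher number from compound 1 to compound 4 (0.56 log units; beyond the scatter), so unlike methylsulfanyl, methoxy moves the number beyond the scatter relative to the unsubstituted compound. The step for methoxy in place of methyl is an at least 45-fold higher number from compound 2 to compound 4 (1.65 log units; beyond the scatter), and its starting value is a limit, not a number: the limit of < 200 nM in this assay, at which 1 of the 4 values shown sits.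

Going by these compounds, whether an amine, a hydroxyl or a longer chain such as ethoxy at this place would push the number higher or bring it back down stays open. The compounds shown also give no reason for the gap between methoxy and methylsulfanyl.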